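The source may report more compounds than this note shows. Statements on the series, on what has been measured and on what is new or still open speak of the compounds shown alone.

Measured compounds and their half-maximal inhibitory concentrations in a functional assay on MDA-MB-231 cells (Homo sapiens) for antiproliferative activity, read by MTT assay, with a stated time of 24 h; a higher number here means a weaker inhibitor, a lower number a stronger inhibitor:
compound 1, `COc1cc(C(=O)/C=C/c2cc(-c3cc(OC)c(OC)c(OC)c3)n3nc(-c4ccccc4)cc3n2)cc(OC)c1OC`: 24300 nM
compound 2, `COc1cc(-c2cc(C(=O)/C=C/c3ccc(Cl)cc3)nc3cc(-c4ccccc4)nn23)cc(OC)c1OC`: 21600 nM
compound 3, `COc1ccc(-c2cc(C(=O)/C=C/c3ccc(Cl)cc3)nc3cc(-c4ccccc4)nn23)cc1OC`: 23700 nM

Compound 3 carries the second highest number of the three, but both compound 1 and compound 2 lie within the scatter of it, so on these numbers the three cannot be told apart. Within the data shown here, the only step that changes a single place, a 1.1-fold higher number from compound 2 to compound 3 (0.04 log units; within the scatter), also stays within the scatter.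

Compound 4, `COc1ccc(-c2cc(/C=C/C(=O)c3ccc(Cl)cc3)nc3cc(-c4ccccc4)nn23)cc1OC`, has not yet been measured in this assay. It differs from compound 3 by 2-((4-chlorophenyl)carbonyl)ethenyl in place of (2-(4-chlorophenyl)ethenyl)carbonyl on an aromatic carbon. The same atoms are present in both, but the carbonyl and the ethenyl that join the shared core to the 4-chlorophenyl ring have exchanged places. Among the measured compounds shown here, none of the measured compounds shows this kind of rearrangement, so no measured step bears on it directly; the one measured step, a 1.1-fold higher number from compound 2 to compound 3 (0.04 log units; within the scatter), concerns a different change and was itself within the scatter. With all three measured numbers close together and nothing pointing in either direction, the expected step of a 1.0-fold higher number from compound 3 to compound 4 (0.01 log units; within the scatter) is none beyond the scatter. For the measured compounds named here, compound 4 is therefore estimated at 24000 nM, with a range from 8000 nM to 72000 nM that is kept wide because no direct precedent exists.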

Compound 4, half-maximal inhibitory concentration: 17100 nM
For compound 4 the middle estimate is 1.4-fold (0.15 log units) above the measured one, and the stated range covers the measured number.
By their numbers in this assay, from the lowest: compounds 4, 2, 3 and 1 (each within the scatter of the next).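

In this assay, among these compounds, the linker itself is tested for the first time: putting 2-((4-chlorophenyl)carbonyl)ethenyl in place of (2-(4-chlorophenyl)ethenyl)carbonyl, on the aromatic carbon next to the ring nitrogen, gives a 1.4-fold lower number from compound 3 to compound 4 (0.14 log units; within the scatter) and stays there. The two groups have the same atoms and the same counts of rings, double bonds and hydrogen-bond acceptors, so this step changes only the order of the carbonyl and the ethenyl, and on these numbers that order cannot be shown to matter at this position. No independent measurement is available that could explain this result.

Both steps shown stay within the scatter, so it remains open whether any change to this linker or to the ring it carries can move the number beyond the scatter. Also open, going by these compounds, is what would happen if an amine or a carboxylic acid took the place of the chlorine on the 4-chlorophenyl ring, or if an amide or a longer chain replaced the carbonyl and ethenyl linker.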